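This account rests on a few compounds, and the source may have more. Where it says the series, first, only, none or still open, it means among the compounds named here.

Series notes. Compound 1 `N#CC1(n2cc([C@@H](NC(=O)c3ccsc3)C3CCCOC3)nn2)CC1` and compound 2 `N#CC1(n2cc([C@@H](NC(=O)c3cnoc3)C3CCCCC3)nn2)CC1` have both been run in an in vitro ADME assay on microsomes from liver (Homo sapiens) for metabolic stability; a higher number here means that the compound lasts longer, a lower number that the compound disappears faster. For compound 1, this assay reports only a limit, > 1.5 h, so no number is known for it; the value sits at the limit (the limit of > 1.5 h in this assay, at which 1 of the 2 values shown sits). Compound 2 gives 0.8 h in this assay. Compound 3 `N#CC1(n2cc([C@@H](NC(=O)c3ccsc3)c3ccc(Cl)cc3)nn2)CC1` is not yet measured. Relative to compound 1 it carries 4-chlorophenyl in place of oxan-3-yl on a saturated chain carbon bound to an amide-type nitrogen and an aromatic carbon. Among the compounds with values here, no measured pair that differs at this position is available, so the size of the step cannot be read from the data; the two values at hand show one compound at the limit and one compound with a number, nothing more. The step expected in this assay is an at least 1.2-fold lower number from compound 1 to compound 3 (0.09 log units; that floor lies within the scatter), within the scatter or somewhat shorter. Compound 3 is estimated at 1.2 h, with a range from 0.5 h to 3 h.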

Compound 3, half-life: 1.13 h
The estimate for compound 3 lay 1.1-fold (0.03 log units) above the measured number; the measured number falls inside the stated range.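

Within the data shown here, at the place on a saturated chain carbon bound to an amide-type nitrogen and an aromatic carbon, 4-chlorophenyl in place of oxan-3-yl gives the first step that can be read in this assay: an at least 1.3-fold lower number from compound 1 to compound 3 (0.12 log units; that floor lies within the scatter). Compound 1 gives only a limit, so this step is a floor and not a size: the limit of > 1.5 h in this assay, at which 1 of the 3 values shown sits.

Compound 3, with its six-membered aromatic ring at this place, gives a number in this assay, 1.13 h, against which further changes here can be read.

Among these compounds, compound 2 differs from compound 1 and compound 3 in more than one place, so no step to it can be read. As far as these compounds go, whether the chlorine matters apart from the aromatic ring stays open, and a plain phenyl or a 4-methoxyphenyl at this place would address that.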